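Replacing nitro with fluoro on an aromatic carbon

The compounds below may be only part of what the source reports. "The series", "measured", "known", "first", "only" and "open" are said of these compounds alone.

Values in a functional assay on HeLa cells (Homo sapiens) for cytotoxicity, read by WST assay, with a stated time of 48 h; a higher number here means a weaker inhibitor, a lower number a stronger inhibitor:
compound 1 `O[C@@H](c1ccccc1)[C@H]1CO[C@H](c2ccccc2)[C@@H](C/C=C/c2ccccn2)C1`: 33800 nM
compound 2 `O=[N+]([O-])c1cccc(/C=C/C[C@H]2C[C@@H]([C@@H](O)c3ccccc3)CO[C@@H]2c2ccccc2)c1`: 7850 nM
compound 3 `O=[N+]([O-])c1ccc(/C=C/C[C@H]2C[C@@H]([C@@H](O)c3ccccc3)CO[C@@H]2c2ccccc2)cc1`: 12400 nM

Compound 3 cannot be separated from compound 2, since the step of a 1.6-fold higher number from compound 2 to compound 3 (0.20 log units; within the scatter) is small, but it clearly differs from compound 1, with a 2.7-fold lower number from compound 1 to compound 3 (0.44 log units; beyond the scatter). Compound 4 `O[C@@H](c1ccccc1)[C@H]1CO[C@H](c2ccccc2)[C@@H](C/C=C/c2ccc(F)cc2)C1` has fluoro in place of nitro on an aromatic carbon. Going by the values given here, no measured step makes this exact swap, so the evidence is indirect. Exchanging the whole aromatic group gave only modest steps, a 4.3-fold lower number from compound 1 to compound 2 (0.63 log units; beyond the scatter) and a 2.7-fold lower number from compound 1 to compound 3 (0.44 log units; beyond the scatter). No change beyond the scatter is therefore expected in this assay, and the estimated step is a 1.2-fold higher number from compound 3 to compound 4 (0.08 log units; within the scatter). The expected value for compound 4 is 15000 nM, with an estimated range of 7000 nM to 32000 nM.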

Compound 4, half-maximal inhibitory concentration: 8340 nM
Beside the measured number, compound 4's estimate is 1.8-fold (0.25 log units) above it, and the stated range covers the measured number.
By their numbers in this assay, from the lowest: compounds 2, 4 and 3 (each within the scatter of the next); then compound 1.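

In this assay, nitro can give way to fluoro on this aromatic carbon with no change that stands out from the scatter (a 1.5-fold lower number from compound 3 to compound 4 (0.17 log units; within the scatter)). The 4-fluorophenyl group also matches the 3-nitrophenyl group (a 1.1-fold higher number from compound 2 to compound 4 (0.03 log units; within the scatter)) and keeps the gain over pyridin-2-yl (a 4.1-fold lower number from compound 1 to compound 4 (0.61 log units; beyond the scatter)), so that gain does not require a nitro group. No measurement here explains why these groups behave alike.

From the compounds shown here alone, whether an amine or a carboxylic acid at this place would keep the same level remains open.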